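The source may hold more compounds than are shown below. What is called first, only, known or untested is meant among the compounds shown, and "the series" means these compounds.

Measured compounds:
- compound 1, `CCCCOCCn1c(N2CCCN(C)CC2)nc2ccccc21`: 10 nM
- compound 2, `CCNCCn1c(N2CCN(C)CC2)nc2ccccc21`: 290 nM

Notes on the series. In a functional assay on ileum for inhibition of histamine H1 receptor (Cavia porcellus) (on this read-out lower numbers stand for stronger inhibition and higher numbers for weaker inhibition), compound 1 gives 10 nM, the lowest of the two numbers recorded. Among the compounds with values here, compound 2 gives 290 nM in this assay, a clearly higher number; compound 2 differs from compound 1 in more than one place, so no single-point step connects the two and only the two values themselves are known.

The next compound, compound 3, `C=CCOCCn1c(N2CCCN(C)CC2)nc2ccccc21`, is the one-point variation of compound 1: vinyl in place of propyl on a saturated chain carbon bound to an oxygen on a saturated carbon The ring system, the side chain on the core and the oxygen in the chain are kept; the chain beyond the oxygen is shortened by one carbon and ends in a double bond.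

Within the data shown here, no step between measured compounds is recorded here, so the size of this change must be estimated without a precedent. Given that compound 1 sits at 10 nM and the change is confined to the end of the chain, the step from compound 1 to compound 3 is expected to be small, at most a slight move toward weaker inhibition and possibly none beyond the scatter: a 1.5-fold higher number from compound 1 to compound 3 (0.18 log units; within the scatter). Compound 3 is therefore estimated at 15 nM in this assay, with a range of 5 nM to 45 nM.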

Compound 3, half-maximal inhibitory concentration: 10 nM
Estimate against measurement, compound 3: 1.5-fold (0.18 log units) above, within the range that was stated.
By their numbers in this assay, from the lowest: compounds 1 and 3 (each within the scatter of the next); then compound 2.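

In this assay, within the data shown here, this pair gives the first single-point reading: vinyl in place of propyl on a saturated chain carbon bound to an oxygen on a saturated carbon gives no change at the digits printed from compound 1 to compound 3 (within the scatter). At this position, then, butoxy and allyloxy read alike, so removing one carbon from the chain end and adding a double bond outside aromatic rings, taken together, leave the read-out unmoved for this pair; compound 2 differs from compound 1 in more than one place and could not show this. No accompanying measurement bears on why the two values coincide.

This one exchange does not show how far the position tolerates change, and a longer chain such as hexyl, a terminal amine, a hydroxyl or a carboxylic acid at the chain end could each read differently. The two structural changes within the exchange, the shorter chain and the double bond, also remain unseparated, and a saturated propyl ether on the same core would be needed to read them apart.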